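Methoxy to hydroxy on a stilbene sulfonamide

A few compounds are considered here, and "the series" means these few. Any claim that something is new, unique, unknown or untested is made for them only; others in the source may bear on it.

Compound 1, `COc1cc(/C=C/c2ccc(S(N)(=O)=O)cc2)cc(OC)c1`: 20100 nM
Compound 2, `COc1cccc(/C=C/c2ccc(S(N)(=O)=O)cc2)c1`: 25500 nM
Compound 3, `NS(=O)(=O)c1ccc(/C=C/c2ccc(F)cc2)cc1`: 23700 nM

These three compounds share one core and were tested in a functional assay on Hs-578T cells (Homo sapiens) for inhibition; a higher number here means a weaker inhibitor of growth, a lower number a stronger inhibitor of growth. Compound 2 has the highest of the three numbers, but its gaps to compound 3 and to compound 1 both lie within the scatter, so no order among them can be read. Compound 4, `NS(=O)(=O)c1ccc(/C=C/c2cccc(O)c2)cc1`, differs from compound 2 in one place: hydrogen in place of methyl on an oxygen on an aromatic ring. Within the data shown here, the only measured step touching this part of the molecule is a 1.3-fold higher number from compound 1 to compound 2 (0.10 log units; within the scatter), where hydrogen in place of methoxy left the number within the scatter. Among the measured compounds shown here, no measured pair swaps methyl for hydrogen on the oxygen itself. The step expected in this assay is a 1.0-fold lower number from compound 2 to compound 4 (0.01 log units; within the scatter), no larger than the scatter. The estimate for compound 4 is 25000 nM, within a range from 8000 nM to 80000 nM.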

Compound 4, concentration for 50% growth inhibition: 61000 nM
Beside the measured number, compound 4's estimate is 2.4-fold (0.39 log units) below it; the range from low to high includes it.
By their numbers in this assay, from the lowest: compounds 1, 3 and 2 (each within the scatter of the next); then compound 4.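

In this assay the change from methoxy to hydroxy gives a 2.4-fold higher number from compound 2 to compound 4 (0.38 log units; beyond the scatter) and so marks a modest loss of growth inhibition. The earlier step, a 1.3-fold higher number from compound 1 to compound 2 (0.10 log units; within the scatter), stayed within the scatter when a whole methoxy gave way to hydrogen. Changing only the methyl on this oxygen therefore moved the number further than that loss of a methoxy did. Going by these compounds, whether an amine or a carboxylic acid in place of the hydroxy would behave like the hydroxy or like the methoxy stays open. No measurement at hand explains the weaker growth inhibition with the hydroxy.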